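Replacing a carboxy group on the shared core: compound 3

The source may report more compounds than this note shows. Statements on the series, on what has been measured and on what is new or still open speak of the compounds shown alone.

Measured so far:
- compound 1, `CCCCN(c1nc2c(C(=O)O)cccc2o1)[C@H](C)c1ccc(-c2ccccc2-c2nnn[nH]2)cc1`: 17 nM
- compound 2, `C[C@H](c1ccc(-c2ccccc2-c2nc(=O)o[nH]2)cc1)N(CC1CC1)c1nc2c(C(=O)O)cccc2o1`: 11 nM

Both compounds were tested in a functional assay on CAL1 cells for inhibition of chemerin-like receptor 1 (Homo sapiens), with a stated time of 45 min; a lower number here means a stronger inhibitor, a higher number a weaker inhibitor. Compound 1 gives 17 nM, and compound 2 gives 11 nM. Compound 1 has the higher of the two numbers, but the gap to compound 2 is within the usual scatter, so the two are not told apart by these measurements.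

Compound 3, `CCCCN(c1nc2c(-c3nccn3C)cccc2o1)[C@H](C)c1ccc(-c2ccccc2-c2nnn[nH]2)cc1`, differs from compound 1 in one place: 1-methyl-1H-imidazol-2-yl in place of carboxy on an aromatic carbon. A 1-methyl-1H-imidazol-2-yl group takes the place of the carboxy group on the aromatic carbon ortho to the fused ring. Among the measured compounds shown here, no pair of measured compounds shows the effect of this change, so no measured step can be used as a guide. For the measured compounds named here, the step from compound 1 to compound 3 is expected to go toward a higher number, that is a weaker inhibitor, of size a 3.5-fold higher number from compound 1 to compound 3 (0.55 log units; beyond the scatter), because compound 1 sits at 17 nM and the change removes the only acidic group on the core. Compound 3 is therefore estimated at 60 nM, with a range from 12 nM to 400 nM.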

Compound 3, half-maximal inhibitory concentration: 10 nM
Compound 3: the middle estimate sits 6.0-fold (0.78 log units) above what was measured; the whole stated range lies above it.
By their numbers in this assay, from the lowest: compounds 3, 2 and 1 (each within the scatter of the next).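

In this assay, placing 1-methyl-1H-imidazol-2-yl on this aromatic carbon instead of carboxy gives a 1.7-fold lower number from compound 1 to compound 3 (0.23 log units; within the scatter), so the two compounds are not told apart by this measurement. For this pair, the position on the shared core therefore accepts a larger group containing a five-membered aromatic ring, and the loss of the hydrogen-bond donor of the carboxy group, whose replacement has none, comes with no change beyond the scatter. This single pair does not show why the two groups give such similar numbers, and no supporting measurement bears on that question.

The compounds shown leave open whether this tolerance extends to other groups at the same place, such as a primary amide, a nitrile or a plain hydrogen, and whether the methyl on the imidazole matters, which a comparison with the unmethylated imidazol-2-yl group would test. They also leave open whether the same swap behaves alike with the cyclopropylmethyl chain of compound 2 in place of the butyl chain.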